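Hydroxyphenyl repositioning on two related cores

This account rests on a few compounds, and the source may have more. Where it says the series, first, only, none or still open, it means among the compounds named here.

Compound 1 `Oc1ccc(-c2cc(-c3cccc(F)c3)cc(-c3cccc(O)c3)n2)cc1` gives 2700 nM in a functional assay on DU-145 cells (Homo sapiens) for inhibition; on this read-out lower numbers stand for stronger inhibition and higher numbers for weaker inhibition. Compound 2 `Oc1ccc(-c2cc(-c3cccc(F)c3)cc(-c3ccc(O)cc3)n2)cc1` gives 9290 nM in this assay; the change is 4-hydroxyphenyl in place of 3-hydroxyphenyl on an aromatic carbon and the step is a 3.4-fold higher number from compound 1 to compound 2 (0.54 log units; beyond the scatter). Compound 3 `Oc1ccc(-c2cc(-c3ccccc3C(F)(F)F)cc(-c3cccc(O)c3)n2)cc1` gives 2750 nM in this assay; its core differs from that of compound 1 by 2-(trifluoromethyl)phenyl in place of 3-fluorophenyl on an aromatic carbon, and the step is a 1.0-fold higher number from compound 1 to compound 3 (0.01 log units; within the scatter), so the two cores sit together.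

Compound 4 `Oc1ccc(-c2cc(-c3ccccc3C(F)(F)F)cc(-c3ccc(O)cc3)n2)cc1` awaits measurement in this assay. It differs from compound 3 by 4-hydroxyphenyl in place of 3-hydroxyphenyl on an aromatic carbon. This is the same kind of change as that from compound 1 to compound 2, the surroundings of the place differing only in that the ring there is meta to a 3-fluorophenyl group, whereas here it is meta to a 2-(trifluoromethyl)phenyl group. Only these two instances of the change are present, so no wider pattern is claimed.

For compound 4 the expected step is a 3.3-fold higher number from compound 3 to compound 4 (0.51 log units; beyond the scatter), resting on compound 1 to compound 2 having shown a 3.4-fold higher number from compound 1 to compound 2 (0.54 log units; beyond the scatter) and on compound 3 standing level with compound 1 at a 1.0-fold higher number from compound 1 to compound 3 (0.01 log units; within the scatter). The estimate for compound 4 is 9000 nM, expected between 4000 nM and 20000 nM.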

Compound 4, half-maximal inhibitory concentration: > 50000 nM
Compound 4 was reported as a limit (the forecaster's own chance of this, stated with the estimate: 10%); middle value at least 5.5-fold (0.74 log units) away from the limit.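

Compound 4 is reported in this assay only as a limit, > 50000 nM, so the new steps can be read only as minimum sizes and their true sizes remain unknown: the limit of > 50000 nM in this assay, at which 1 of the 4 values shown sits.

Placing 4-hydroxyphenyl in place of 3-hydroxyphenyl gives a higher number on both cores, but the size does not carry over, with an at least 18-fold higher number from compound 3 to compound 4 (1.25 log units; beyond the scatter) on the second core: the same change on two cores in this assay, a 3.4-fold higher number (0.54 log units; beyond the scatter) from compound 1 to compound 2 and an at least 18-fold higher number (1.25 log units; beyond the scatter) from compound 3 to compound 4, at least 5.2-fold (0.72 log units) apart, beyond the scatter of two such steps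

The exchange of 3-fluorophenyl for 2-(trifluoromethyl)phenyl likewise depends on the compound that carries it, giving an at least 5.3-fold higher number from compound 2 to compound 4 (0.73 log units; beyond the scatter) although compound 1 and compound 3 sit level, and these two pairs set no general rule for the series: the same change on two cores in this assay, a 1.0-fold higher number (0.01 log units; within the scatter) from compound 1 to compound 3 and an at least 5.3-fold higher number (0.73 log units; beyond the scatter) from compound 2 to compound 4, at least 5.2-fold (0.72 log units) apart, beyond the scatter of two such steps

The compounds shown leave open whether the same dependence would appear with other aryl groups, such as a 3-chlorophenyl or a 4-methoxyphenyl, in place of 2-(trifluoromethyl)phenyl. They also leave open how this read-out would respond if an amine or a carboxylic acid replaced the hydroxyl on either hydroxyphenyl ring.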